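The source may report more compounds than this note shows. Statements on the series, on what has been measured and on what is new or still open speak of the compounds shown alone.

Measured compounds:
compound 1, `CC[C@H](CCn1cncn1)c1ccc(C)cc1`, 75.2 ug/mL
compound 2, `CCC[C@H](CCn1cncn1)c1ccccc1`, 58.4 ug/mL
compound 3, `CCC[C@H](CCn1cncn1)c1ccc(F)cc1`, 39.3 ug/mL

All three were tested in an ADME assay on HEp-2 cells (Homo sapiens) for cytotoxicity, read by MTT assay, with a stated time of 3 days; on this read-out higher numbers stand for lower toxicity in this test and lower numbers for higher toxicity in this test. Compound 3 gives the lowest of the three numbers, but both other compounds sit within the scatter of it: compound 2 gives 58.4 ug/mL and compound 1 gives 75.2 ug/mL, so no order among the three can be drawn. Among the compounds with values here, the only single-point step between measured compounds is a 1.5-fold lower number from compound 2 to compound 3 (0.17 log units; within the scatter), and it is within the scatter.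

Compound 4, `CCC[C@H](CCn1cncn1)c1ccc(C)cc1`, differs from compound 3 by methyl in place of fluoro on an aromatic carbon. The step from compound 2 to compound 3 bears on this change, since it also altered the same aromatic carbon, and it was small. Compound 4 shares the methyl on the aromatic ring with compound 1, which differs elsewhere; compound 1 gives 75.2 ug/mL. Within the data shown here, no single-point step connects compound 1 to compound 4, so only its value can be weighed. Nothing among these compounds points to a step beyond the scatter. Compound 4 is therefore expected to give 55 ug/mL, in the range 30 ug/mL to 100 ug/mL. The expected step is a 1.4-fold higher number from compound 3 to compound 4 (0.15 log units; within the scatter).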

Compound 4, half-maximal cytotoxic concentration: 45.7 ug/mL
Compound 4: middle estimate off by 1.2-fold (0.08 log units), on the high side; low and high end bracket the measured number.
By their numbers in this assay, from the lowest: compounds 3, 4, 2 and 1 (each within the scatter of the next).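

Within the data shown here, with this assay as the read-out, methyl in place of fluoro on this aromatic carbon, para to a large group, gives a 1.2-fold higher number from compound 3 to compound 4 (0.07 log units; within the scatter) and methyl in place of hydrogen on the same carbon gives a 1.3-fold lower number from compound 2 to compound 4 (0.11 log units; within the scatter) so that hydrogen, fluoro and methyl at this position now stand within the scatter of one another, a three-way comparison that the single step among the earlier compounds could not offer. With the methyl held on the ring, the other listed difference can also be read for the first time: methyl in place of hydrogen on a saturated chain carbon, three bonds along the chain from an aromatic carbon, gives a 1.6-fold lower number from compound 1 to compound 4 (0.22 log units; within the scatter) and so this chain difference does not separate the two compounds in this test either. No measurement at hand accounts for these numbers.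

The compounds shown leave open whether an amine, a carboxylic acid or a methoxy group on this aromatic carbon would give a number beyond the scatter. They also leave open whether a longer chain at the saturated end would do so, alone or together with a group on the ring.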